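A few compounds are considered here, and "the series" means these few. Any claim that something is new, unique, unknown or untested is made for them only; others in the source may bear on it.

Working notes on the series. Of the compounds shown here, three of the shared core have been measured in a functional assay on MCF7 cells (Homo sapiens) for antiproliferative activity, read by MTT assay, with a stated time of 72 h; a higher number here means a weaker inhibitor, a lower number a stronger inhibitor. Going by the values given here, compound 1 `O=C(COc1ccc(C(=O)/C=C/c2ccccc2Cl)cc1)N[C@H]1CCOC1=O` gives 17400 nM, the only determined number in the set. Compound 2 `CCOc1ccccc1OCCSC(=S)N[C@H]1CCOC1=O` returns only a limit of the assay, > 64000 nM. Compound 3 `O=C(CNc1cccc(Cl)c1)N[C@H]1CCOC1=O` likewise returns only a limit, > 64000 nM. Among the compounds with values here, compound 1 is thus the one compound with a measured value; the other two sit at the limit of > 64000 nM in this assay, at which 2 of the 3 values shown sit, so no ordering among the three can be read from the numbers.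

Compound 4 `O=C(COc1ccc(C(=O)/C=C/c2ccccc2)cc1)N[C@H]1CCOC1=O` has not yet been measured in this assay. It differs from compound 1 in one place: hydrogen in place of chloro on an aromatic carbon. Within the data shown here, no measured pair in the set carries this change, so its size is not known from the data. Hydrogen in place of chloro on an aromatic carbon is a small change, and the expected step is a 1.4-fold higher number from compound 1 to compound 4 (0.16 log units; within the scatter), not clearly beyond the scatter, with a slight weakening as the more likely direction. Compound 4 is estimated at 25000 nM in this assay, within a range of 9000 nM to 64000 nM.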

Compound 4, half-maximal inhibitory concentration: > 64000 nM
Compound 4 was reported as a limit; the forecaster's own chance of this, stated with the estimate: 25%; middle value at least 2.5-fold (0.40 log units) away from the limit.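

Going by these compounds alone, the change from 2-chlorophenyl to phenyl, on an aromatic carbon ortho to a large group, gives the first step that can be read in this assay: it is an at least 3.6-fold higher number from compound 1 to compound 4 (0.56 log units; beyond the scatter). Within this pair, the determined value of compound 1 is lost when one chlorine atom leaves, so this small change is not silent at this position. Compound 4 gives > 64000 nM, which is a limit of the assay and not a number, so only a bound on the step is known, and compound 4 joins the values at that limit: the limit of > 64000 nM in this assay, at which 3 of the 4 values shown sit.

The compounds shown leave open whether chloro is specifically required at this place or whether fluoro, methyl or methoxy would serve equally. They also leave open how chloro would behave on another carbon of that ring.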